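A few compounds are considered here, and "the series" means these few. Any claim that something is new, unique, unknown or untested is made for them only; others in the source may bear on it.

Measured compounds:
compound 1, `O=C(O)Cc1sc(C(c2ccc(F)cc2)c2ccc(F)cc2)nc1-c1ccc(Cl)cc1`, giving 180 nM in an in vitro functional assay on HEK285-7 cells for antagonist activity at prostaglandin D2 receptor 2 (Homo sapiens), read by BRET and beta-arrestin recruitment; on this read-out lower numbers stand for stronger inhibition and higher numbers for weaker inhibition
compound 2, `N#Cc1ccc(-c2nc(C(c3ccc(F)cc3)c3ccc(F)cc3)sc2CC(=O)O)cc1`, giving 1500 nM in this assay
compound 3, `NS(=O)(=O)c1cccc(-c2nc(C(c3ccc(F)cc3)c3ccc(F)cc3)sc2CC(=O)O)c1`, giving 710 nM in this assay

Compound 3 holds the second highest of the three numbers in this assay. Its nearest neighbour is compound 2, with a 2.1-fold lower number from compound 2 to compound 3 (0.32 log units; beyond the scatter), and its furthest is compound 1, with a 3.9-fold higher number from compound 1 to compound 3 (0.60 log units; beyond the scatter). Compound 4, `O=C(O)Cc1sc(C(c2ccc(F)cc2)c2ccc(F)cc2)nc1-c1ccoc1`, differs from compound 3 in one place: furan-3-yl in place of 3-sulfamoylphenyl on an aromatic carbon. For the measured compounds named here, the steps that bear on this change are those that altered the same ring on the shared core: a 3.9-fold higher number from compound 1 to compound 3 (0.60 log units; beyond the scatter), a 2.1-fold lower number from compound 2 to compound 3 (0.32 log units; beyond the scatter) and an 8.3-fold higher number from compound 1 to compound 2 (0.92 log units; beyond the scatter). All three were modest, and the 4-chlorophenyl of compound 1 gave the lowest number while the cyano- and sulfamoyl-bearing rings gave higher ones. Going by the values given here, no measured compound carries a five-membered ring at this position, and furan-3-yl brings no hydrogen-bond donor, so the direction is uncertain; a modest step in this assay, likelier downward than upward, is expected. Compound 4 is therefore estimated at 450 nM, with a range from 120 nM to 1800 nM, corresponding to an expected 1.6-fold lower number from compound 3 to compound 4 (0.20 log units; within the scatter).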

Compound 4, half-maximal inhibitory concentration: 130 nM
The estimate for compound 4 lay 3.5-fold (0.54 log units) above the measured number, and the stated range covers the measured number.
By their numbers in this assay, from the lowest: compounds 4 and 1 (each within the scatter of the next); then compound 3; then compound 2.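

In this assay, the aromatic carbon next to the ring nitrogen tolerates a five-membered aromatic ring, which none of the earlier compounds could show: furan-3-yl gives a 5.5-fold lower number from compound 3 to compound 4 (0.74 log units; beyond the scatter) and a 12-fold lower number from compound 2 to compound 4 (1.06 log units; beyond the scatter), the only step among these compounds printed as large. A six-membered ring is therefore not required here, since the change from 4-chlorophenyl to furan-3-yl gives a 1.4-fold lower number from compound 1 to compound 4 (0.14 log units; within the scatter), which lies within the scatter and leaves compound 1 and compound 4 unordered. Nothing given here accounts for these differences.

The compounds shown leave open whether the furan oxygen matters, which a comparison with thiophen-3-yl or an unsubstituted phenyl ring could test. They also leave open how furan-2-yl at this position would compare, and whether a longer chain than the carboxymethyl group would be accepted.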